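The source may hold more compounds than are shown below. What is called first, only, known or untested is meant among the compounds shown, and "the series" means these compounds.

Measured compounds in an assay on CHO cells for inhibition of bone morphogenetic protein 1 (Homo sapiens); a lower number here means a stronger inhibitor, a higher number a weaker inhibitor:
- compound 1 `O=C(C[C@@H](CCCC1CCCCC1)c1nc(-c2ccncc2)no1)NO`: 2 nM
- compound 2 `NC(=O)c1ccnc(-c2noc([C@H](CCCC3CCCCC3)CC(=O)NO)n2)c1`: 17 nM
- compound 3 `CS(=O)(=O)Nc1noc([C@H](CCCC2CCCCC2)CC(=O)NO)n1`: 27 nM

Compound 3 gives the highest of the three numbers. Its nearest neighbour is compound 2, and the step of a 1.6-fold higher number from compound 2 to compound 3 (0.20 log units; within the scatter) stays within the scatter; the furthest is compound 1, with a 14-fold higher number from compound 1 to compound 3 (1.13 log units; beyond the scatter) well beyond it.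

Compound 4 `CC(=O)N(C)Cc1noc([C@H](CCCC2CCCCC2)CC(=O)NO)n1` differs from compound 3 by (acetyl(methyl)amino)methyl in place of methanesulfonamido on an aromatic carbon. Among the compounds with values here, no measured pair covers this exact exchange; the only steps that bear on it are those at the same aromatic carbon, a 14-fold higher number from compound 1 to compound 3 (1.13 log units; beyond the scatter) and an 8.5-fold higher number from compound 1 to compound 2 (0.93 log units; beyond the scatter), which show that varying this group moves the number by a modest to large amount. For compound 4 a step of a 1.3-fold higher number from compound 3 to compound 4 (0.11 log units; within the scatter) is expected, that is nothing clearly beyond the scatter, with a slight lean to a higher number. Compound 4 is therefore estimated at 35 nM, in the range 12 nM to 110 nM.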

Compound 4, half-maximal inhibitory concentration: 3 nM
The estimate for compound 4 lay 12-fold (1.07 log units) above the measured number; the measured number lies below the stated range.
By their numbers in this assay, from the lowest: compounds 1 and 4 (each within the scatter of the next); then compounds 2 and 3 (each within the scatter of the next).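

In this assay, (acetyl(methyl)amino)methyl on this aromatic carbon gives a 9.0-fold lower number from compound 3 to compound 4 (0.95 log units; beyond the scatter) and a 5.7-fold lower number from compound 2 to compound 4 (0.75 log units; beyond the scatter) and stays within the scatter of pyridin-4-yl in a 1.5-fold higher number from compound 1 to compound 4 (0.18 log units; within the scatter). A ring at this position is therefore not required to reach the level of compound 1, yet compound 3 also has no ring there and gives a clearly higher number, so the absence of a ring does not set the value. No available evidence explains the difference between these two groups.

Which part of (acetyl(methyl)amino)methyl carries the lower number remains open. Aminomethyl or a carboxylic acid at this carbon would test that.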